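Chain Growth at the Carbonyl Side Chain of Three Agonists

This account rests on a few compounds, and the source may have more. Where it says the series, first, only, none or still open, it means among the compounds named here.

Compound 1 `CCCOC(=O)N1CCC(Oc2ncnc3c2CCN3c2ccc(S(C)(=O)=O)cc2F)CC1`: 79.4 nM
Compound 2 `CCCCOC(=O)N1CCC(Oc2ncnc3c2CCN3c2ccc(S(C)(=O)=O)cc2F)CC1`: 50.1 nM
Compound 3 `CCSC(=O)N1CCC(Oc2ncnc3c2CCN3c2ccc(S(C)(=O)=O)cc2F)CC1`: 31.6 nM

These three compounds were tested in a functional assay on CHO-K1 cells for agonist activity at Glucose-dependent insulinotropic receptor (Homo sapiens), read by a luciferase reporter, with a stated time of 5 h; a lower number here means that less compound is needed, a higher number that more compound is needed for the effect. They share one core and differ only in the group on the carbonyl carbon: compound 1 carries propoxy, compound 2 butoxy, compound 3 ethylsulfanyl. The change from compound 1 to compound 2 is methyl in place of hydrogen on a saturated chain carbon, three bonds along the chain from an oxygen next to a carbonyl group, and it gave a 1.6-fold lower number from compound 1 to compound 2 (0.20 log units; within the scatter). The pair compound 1 and compound 3 gave a 2.5-fold lower number from compound 1 to compound 3 (0.40 log units; beyond the scatter), and the pair compound 2 and compound 3 gave a 1.6-fold lower number from compound 2 to compound 3 (0.20 log units; within the scatter). Compound 3 has the lowest number of the three, but since its step to compound 2 is within the scatter it cannot be called the most potent.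

Compound 4 `CC(C)SC(=O)N1CCC(Oc2ncnc3c2CCN3c2ccc(S(C)(=O)=O)cc2F)CC1` has not yet been measured. It differs from compound 3 by methyl in place of hydrogen on a saturated chain carbon bound to a saturated chain carbon and a sulfur. This is the same kind of change as from compound 1 to compound 2, not the same one: there the methyl entered on a saturated chain carbon, three bonds along the chain from an oxygen next to a carbonyl group, whereas here it enters on a saturated chain carbon bound to a saturated chain carbon and a sulfur. The two cores themselves differ by ethylsulfanyl in place of propoxy on a carbonyl carbon.

Because the earlier step of a 1.6-fold lower number from compound 1 to compound 2 (0.20 log units; within the scatter) stayed within the scatter, compound 4 is expected to move little from compound 3, estimated as a 1.3-fold lower number from compound 3 to compound 4 (0.10 log units; within the scatter). Compound 4 is thus estimated at 25 nM, expected to lie between 10 nM and 63 nM.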

Compound 4, half-maximal effective concentration: 10 nM
Beside the measured number, compound 4's estimate is 2.5-fold (0.40 log units) above it, within the range that was stated.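

In this assay, methyl in place of hydrogen on a saturated chain carbon bound to a saturated chain carbon and a sulfur gave a 3.2-fold lower number from compound 3 to compound 4 (0.50 log units; beyond the scatter), while isopropylsulfanyl gave a 5.0-fold lower number from compound 2 to compound 4 (0.70 log units; beyond the scatter) in place of butoxy and a 7.9-fold lower number from compound 1 to compound 4 (0.90 log units; beyond the scatter) in place of propoxy, so that compound 4 is the most potent of the four. The added methyl lowered the number on both cores, and the two steps cannot be told apart: the same change on two cores in this assay, a 1.6-fold lower number (0.20 log units; within the scatter) from compound 1 to compound 2 and a 3.2-fold lower number (0.50 log units; beyond the scatter) from compound 3 to compound 4, 2.0-fold (0.30 log units) apart, within the scatter of two such steps. Going by these compounds alone, this is consistent with the change carrying over from one core to the other, but it rests on only two pairs, only the step to compound 4 lies beyond the scatter, and the methyl enters at a different place in each pair, so it does not show that the step has a fixed size or that it would hold on a further core.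

The compounds shown leave open how isopropoxy on the carbonyl carbon would compare with the isopropylsulfanyl of compound 4, a comparison that would differ in one place only. They also leave open where propylsulfanyl, a longer chain, or tert-butylsulfanyl would fall in this assay.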